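Changing one stereocentre in a series at its limit

The source may hold more compounds than are shown below. What is called first, only, known or untested is meant among the compounds shown, and "the series" means these compounds.

In an ADME assay on HCC95 cells (Homo sapiens) for inhibition, read by CellTiter-Glo, with a stated time of 72 h (on this read-out higher numbers stand for an effect only at larger amounts of compound and lower numbers for an effect already at smaller amounts), compound 3 (`Cc1cccc(C(=O)N[C@@H]2C(=O)Nc3c(c(C)nn3-c3ccccc3)[C@@H]2c2ccc(F)cc2)c1`) gives > 25000 nM, which is a limit of the assay. Compound 1 (`Cc1cccc(C(=O)N[C@@H]2C(=O)Nc3c(c(C)nn3C3CCCC3)[C@@H]2c2ccc(F)cc2)c1`) gives > 25000 nM, also a limit. Compound 2 (`Cc1ccc([C@H]2c3c(C)nn(-c4ccccc4)c3NC(=O)[C@H]2NC(=O)c2cccc(C)c2)cc1`) gives > 25000 nM, again a limit. The record so far is the limit of > 25000 nM in this assay, at which 3 of the 3 values shown sit.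

Compound 4 (`Cc1cccc(C(=O)N[C@H]2C(=O)Nc3c(c(C)nn3-c3ccccc3)[C@@H]2c2ccc(F)cc2)c1`) is compared with compound 3 on one point: the two compounds have the same atoms and bonds and differ only in configuration as drawn: 1 of 2 stereo elements differ; a stereocentre at a saturated ring carbon is drawn S in compound 3 and R in compound 4.

Phenyl in place of cyclopentyl on an aromatic nitrogen is a step that the two limits leave unreadable from compound 1 to compound 3. Fluoro in place of methyl on an aromatic carbon is a step that the two limits leave unreadable from compound 2 to compound 3. Neither step alters configuration, and neither offers a size to carry over. In this assay, for the measured compounds named here, no readable change is the main expectation, with a shift to lower numbers the only direction open to measurement.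

The expected change is an at least 1.2-fold lower number from compound 3 to compound 4 (0.09 log units; that floor lies within the scatter). For compound 4 the estimate is 20000 nM, with an expected range of 4000 nM to 30000 nM.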

Compound 4, half-maximal effective concentration: > 25000 nM
Compound 4: no number, only a limit (the forecaster's own chance of this, stated with the estimate: 70%); middle value at least 1.2-fold (0.09 log units) from the limit.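

Compound 4 gives > 25000 nM in this assay, a limit of the assay, and with compound 3 also at a limit, no step can be read between them. The compounds shown leave open whether this stereocentre affects the read-out at all.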